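The source may hold more compounds than are shown below. What is called first, only, known or untested is meant among the compounds shown, and "the series" means these compounds.

Measured so far:
compound 1, `O=C(O)Cc1sc(C(c2ccccc2)c2ccccc2)nc1-c1cccc(F)c1`, 2.9 nM
compound 2, `N#Cc1ccc(-c2nc(C(c3ccc(F)cc3)c3ccc(F)cc3)sc2CC(=O)O)cc1`, 150 nM

Both numbers come from an in vitro assay on HEK385-7 cells for displacement of a labelled ligand from prostaglandin D2 receptor 2 (Homo sapiens); a higher number here means a weaker inhibitor, a lower number a stronger inhibitor. Compound 2 stands at the highest of the two numbers; the nearest, compound 1, gives a number lower by a margin well beyond the usual scatter, so compound 2 is clearly the weaker of the pair. The two differ in more than one place, so their values alone do not tell which change matters.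

Compound 3, `O=C(O)Cc1sc(C(c2ccc(F)cc2)c2ccc(F)cc2)nc1-c1ccnc(F)c1`, has not yet been measured. It differs from compound 2 in a single place: 2-fluoropyridin-4-yl in place of 4-cyanophenyl on an aromatic carbon. Among the measured compounds shown here, compound 1, the only compound with a low number, carries a fluorine-bearing aromatic ring at this place, whereas compound 2 carries the 4-cyanophenyl group. On that ground alone, the step of a 3.8-fold lower number from compound 2 to compound 3 (0.57 log units; beyond the scatter) is expected to move the number downward, by a modest amount that could still fall within the scatter. For compound 3 in this assay the estimate is 40 nM, with a likely range from 8 nM to 200 nM.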

Compound 3, half-maximal inhibitory concentration: 0.48 nM
Beside the measured number, compound 3's estimate is 83-fold (1.92 log units) above it; measured number outside the range, below it.
By their numbers in this assay, from the lowest: compound 3; then compound 1; then compound 2.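

In this assay, putting 2-fluoropyridin-4-yl in place of 4-cyanophenyl gives a 310-fold lower number from compound 2 to compound 3 (2.49 log units; beyond the scatter) while the rest of the molecule stays the same. This shows that the group on this aromatic carbon, next to the ring nitrogen, can move the number by a large margin on its own, which compounds 1 and 2 could not show as they differ in more than one place. The change swaps a nitrile-bearing carbon ring for a ring holding a nitrogen and a fluorine, and no measurement here explains the step.

As far as these compounds go, it remains open whether the ring nitrogen or the fluorine matters more. A plain pyridin-4-yl group or a 2-chloropyridin-4-yl group at this place would help separate the two.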